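Swapping a Ring for a Fluorinated Chain on a Shared Core

This account rests on a few compounds, and the source may have more. Where it says the series, first, only, none or still open, it means among the compounds named here.

Compound 1, `CC[C@@H]1C(=O)N(C)c2cnc(-n3ccnc3-c3ccccc3)nc2N1[C@H]1CCOC1`, was measured in a physicochemical assay for lipophilicity (a higher number here means a more lipophilic compound, a lower number a more polar compound), and gave 1.9. Compound 2, `CCC1C(=O)N(C)c2cnc(-n3ccnc3-c3ccccc3)nc2N1c1ccccc1`, shares the same core but carries a phenyl ring on the same nitrogen; in this assay compound 2 gives 3.3. On these two numbers compound 1 stands lowest, and compound 2 lies higher by a gap beyond the usual scatter. Compound 3, `CC[C@@H]1C(=O)N(C)c2cnc(-n3ccnc3-c3ccccc3)nc2N1CCC(F)(F)F`, has not yet been measured in this assay. It differs from compound 1 in one place: 3,3,3-trifluoropropyl in place of oxolan-3-yl on a nitrogen on an aromatic ring in a ring. The group that leaves holds one hydrogen-bond acceptor and a ring; the group that enters holds none and no ring. The step from compound 1 to compound 3 is expected to raise the partition coefficient by a number 0.80 log units higher from compound 1 to compound 3 (beyond the scatter), a change beyond the scatter. Compound 3 is therefore estimated at 2.7, in a range from 2.2 to 3.2.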

Compound 3, partition coefficient: 3.1
The estimate for compound 3 lay 0.40 log units below the measured number, and the stated range covers the measured number.
By their numbers in this assay, from the lowest: compound 1; then compounds 3 and 2 (each within the scatter of the next).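

In this assay, the swap of oxolan-3-yl for 3,3,3-trifluoropropyl gives a number 1.20 log units higher from compound 1 to compound 3 (beyond the scatter), a large step. Within the data shown here, this is the first one-place reading at this nitrogen, and it shows that the number for the shared core depends strongly on the group placed there. The swap removes the ring and the oxygen and adds the fluorines all at once, and nothing available shows which of these changes accounts for the step.

A plain propyl chain would show what the same chain gives without its fluorines, while a cyclopentyl ring would keep the ring and lose the oxygen. On these data alone, how a chain ending in an amine or a carboxylic acid would read at this nitrogen also remains open.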